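Methoxy added to a chromone core: expected cytotoxicity

The source may hold more compounds than are shown below. What is called first, only, known or untested is meant among the compounds shown, and "the series" means these compounds.

Compound 1 `CC(=O)Nc1ccc(O)c(C(=O)/C=C/c2ccccc2)c1`: 49400 nM; compound 2 `COc1ccc(/C=C/C(=O)c2cc(NC(C)=O)ccc2O)cc1`: 38700 nM; compound 3 `CC(=O)Nc1ccc2oc(-c3ccccc3)c(O)c(=O)c2c1`: 64700 nM.

All three were tested in an ADME assay on MT4 cells (Homo sapiens) for cytotoxicity, read by MTT assay, with a stated time of 4 days; on this read-out higher numbers stand for lower toxicity in this test and lower numbers for higher toxicity in this test. Compound 2 differs from compound 1 by methoxy in place of hydrogen on an aromatic carbon; this gave a 1.3-fold lower number from compound 1 to compound 2 (0.11 log units; within the scatter). The difference between the core of compound 1 and the core of compound 3 is not broken down here. Compound 4 `COc1ccccc1-c1oc2ccc(NC(C)=O)cc2c(=O)c1O` is not yet measured; it differs from compound 3 by methoxy in place of hydrogen on an aromatic carbon. Among the measured compounds shown here, this is the same kind of change as the one from compound 1 to compound 2, but the place differs: in compound 2 the methoxy sits para to a large group, in compound 4 ortho to a large group. Because the earlier step was a 1.3-fold lower number from compound 1 to compound 2 (0.11 log units; within the scatter), a similarly small step is expected, namely a 1.3-fold lower number from compound 3 to compound 4 (0.11 log units; within the scatter). Compound 4 is therefore estimated at 50000 nM in this assay .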

Compound 4, half-maximal cytotoxic concentration: 385000 nM
The estimate for compound 4 lay 7.7-fold (0.89 log units) below the measured number, outside the stated range (above it).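

In this assay, methoxy in place of hydrogen gave a 6.0-fold higher number from compound 3 to compound 4 (0.77 log units; beyond the scatter), a step beyond the scatter towards lower toxicity in this test. The step seen on the core of compound 1 did not carry over to the core of compound 3, and the two steps differ: the same change on two cores in this assay, a 1.3-fold lower number (0.11 log units; within the scatter) from compound 1 to compound 2 and a 6.0-fold higher number (0.77 log units; beyond the scatter) from compound 3 to compound 4, 7.6-fold (0.88 log units) apart, beyond the scatter of two such steps. This shows that a step measured on one core cannot simply be transferred to the other here, but it does not show whether the core or the place of the methoxy decides the outcome, as compound 2 and compound 4 differ in both.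

The compounds shown leave open whether this step is particular to methoxy or would also appear with another group, such as an amine or a chlorine atom, ortho to a large group on the core of compound 3. They also leave open what methoxy does elsewhere on that ring.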